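The source may hold more compounds than are shown below. What is called first, only, known or untested is meant among the compounds shown, and "the series" means these compounds.

Measured compounds:
- compound 1 `O=C(c1ccccc1)N1CCc2oc(-c3ccc(Br)cn3)nc2C1` gives 174 nM in a functional assay on HEK293 cells for negative allosteric modulation of metabotropic glutamate receptor 5 (Homo sapiens), read by fluorescence and calcium flux, with a stated time of 2 min; on this read-out lower numbers stand for stronger inhibition and higher numbers for weaker inhibition
- compound 2 `N#Cc1ccc(-c2nc3c(o2)CCN(C(=O)c2ccccc2)C3)nc1` gives 237 nM in this assay
- compound 3 `O=C(c1ccccc1F)N1CCc2oc(-c3ccc(F)cn3)nc2C1` gives 58 nM in this assay

Compound 3 has the lowest number of the three. Against compound 1 the gap is beyond the scatter, and against compound 2 the gap is wider still; compound 3 differs from both at two places, so those gaps are not single steps. Within the data shown here, the one single step available, a 1.4-fold higher number from compound 1 to compound 2 (0.13 log units; within the scatter), concerns the ring attached to the shared core and not the benzoyl ring.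

Compound 4 `O=C(c1cccc(Cl)c1)N1CCc2oc(-c3ccc(F)cn3)nc2C1` carries 3-chlorophenyl in place of 2-fluorophenyl on a carbonyl carbon. Among the measured compounds shown here, no measured step touches the benzoyl ring, so nothing here tells the direction of this change in this assay. For the measured compounds named here, the only guidance is that compound 3, which carries the 2-fluorophenyl, holds the lowest number, so a return toward the numbers of compound 1 and compound 2 is as plausible as staying level. Compound 4 is therefore expected to give about 120 nM, with a range from 40 nM to 400 nM, which means an estimated step of a 2.1-fold higher number from compound 3 to compound 4 (0.32 log units; beyond the scatter) — a modest rise, not confidently beyond the scatter.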

Compound 4, half-maximal inhibitory concentration: 50 nM
Compound 4: middle estimate off by 2.4-fold (0.38 log units), on the high side, within the range that was stated.
By their numbers in this assay, from the lowest: compounds 4 and 3 (each within the scatter of the next); then compounds 1 and 2 (each within the scatter of the next).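

In this assay, the phenyl ring on a carbonyl carbon whose other neighbours are an amide-type nitrogen in a ring now has its first single step, a 1.2-fold lower number from compound 3 to compound 4 (0.06 log units; within the scatter), with 3-chlorophenyl in place of 2-fluorophenyl. For this pair, changing both the halogen and the printed ring position leaves the number within the scatter, so this read-out does not separate the two groups. Nothing available bears on why the two groups read alike.

As far as these compounds go, compound 3 and compound 4 share everything outside this position, so it stays open whether the two groups also read alike when paired with the bromo or cyano groups of compound 1 and compound 2. Also open, from the compounds shown here alone, is how this position responds to a phenyl ring carrying an amine or a carboxylic acid, or to a longer chain in place of the ring.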